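A Larger Aryl Group on the Shared Core

The source may hold more compounds than are shown below. What is called first, only, known or untested is meant among the compounds shown, and "the series" means these compounds.

Three compounds built on one shared core were tested in a functional assay on MDA-MB-231 cells (Homo sapiens) for antiproliferative activity, read by MTT assay, with a stated time of 72 h; a higher number here means a weaker inhibitor, a lower number a stronger inhibitor. Compound 1 `O=C(Nc1cccc(-c2nc(-c3ccc(NC(=O)c4cccnc4)cc3Cl)no2)c1)c1ccccc1` gives 12800 nM. Compound 2 `O=C(Nc1ccccc1)Nc1cccc(-c2nc(-c3ccc(NC(=O)c4cccnc4)cc3Cl)no2)c1` reaches only > 10000 nM, which is a limit of the assay and not a number (the limit of > 10000 nM in this assay, at which 1 of the 3 values shown sits). Compound 3 `COc1ccc(NC(=O)Nc2cccc(-c3nc(-c4ccc(NC(=O)c5cccnc5)cc4Cl)no3)c2)cc1` gives 3000 nM, the lowest of the two numbers, with the step of a 4.3-fold lower number from compound 1 to compound 3 (0.63 log units; beyond the scatter) and the step of an at least 3.3-fold lower number from compound 2 to compound 3 (0.52 log units; beyond the scatter) both moving the same way. Compound 4 `CS(=O)(=O)Nc1ccc(NC(=O)Nc2cccc(-c3nc(-c4ccc(NC(=O)c5cccnc5)cc4Cl)no3)c2)cc1Cl` differs from compound 3 by 3-chloro-4-(methanesulfonamido)phenyl in place of 4-methoxyphenyl on an amide-type nitrogen. Both measured steps concern this same end of the molecule and were modest in size, yet neither involves the entering group, so only a small shift, in either direction, is expected: a 1.2-fold lower number from compound 3 to compound 4 (0.08 log units; within the scatter). Compound 4 is therefore estimated at 2500 nM, within 600 nM to 9000 nM.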

Compound 4, half-maximal inhibitory concentration: 600 nM
Beside the measured number, compound 4's estimate is 4.2-fold (0.62 log units) above it; the measured number falls inside the stated range.
By their numbers in this assay, from the lowest: compound 4; then compound 3; then compound 1.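

Changing the aryl group on the amide-type nitrogen once more gives a 5.0-fold lower number from compound 3 to compound 4 (0.70 log units; beyond the scatter), so the gain at this position did not end with 4-methoxyphenyl. Measured from the unsubstituted phenyl, the change gives an at least 16-fold lower number from compound 2 to compound 4 (1.22 log units; beyond the scatter), the largest step seen so far on this core. Compound 2 stands at a limit and not at a number: the limit of > 10000 nM in this assay, at which 1 of the 4 values shown sits.

From the compounds shown here alone, the new group brings the chloro and the methanesulfonamido together, so how the step divides between them stays open. Going by these compounds, whether an amine or a carboxylic acid in place of the methanesulfonamido group would do the same also stays open.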